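From trifluoromethoxy to methoxy on a growth inhibitor

The source may report more compounds than this note shows. Statements on the series, on what has been measured and on what is new or still open speak of the compounds shown alone.

- compound 1 `Oc1cccc2[nH]c(-c3ccc(-c4ccc(-c5ccc(F)cc5)cc4)cc3)nc12` with 22200 nM measured
- compound 2 `Oc1cccc2[nH]c(-c3ccc(-c4ccc(-c5ccc(OC(F)(F)F)cc5)cc4)cc3)nc12` with 3100 nM measured

In a functional assay on DWD cells (Homo sapiens) for inhibition, read by sulforhodamine B assay (a lower number here means a stronger inhibitor of growth, a higher number a weaker inhibitor of growth), compound 2 stands at 3100 nM as the lower of the two numbers. Compound 3 `COc1ccc(-c2ccc(-c3ccc(-c4nc5c(O)cccc5[nH]4)cc3)cc2)cc1` has not been measured yet. It carries methyl in place of trifluoromethyl on an oxygen on an aromatic ring which turns trifluoromethoxy to methoxy. Within the data shown here, only one measured step touches the same end of the molecule, namely a 7.2-fold lower number from compound 1 to compound 2 (0.85 log units; beyond the scatter) where trifluoromethoxy replaced fluoro. Among the measured compounds shown here, it shows that this end can shift the number, but no methoxy compound has been measured to show how far. A modest rise towards the value of compound 1 therefore seems likely, meaning somewhat weaker growth inhibition. The expected step is a 2.3-fold higher number from compound 2 to compound 3 (0.35 log units; beyond the scatter) in this assay with wide uncertainty. For compound 3 the estimate is 7000 nM with an expected range from 2000 nM to 25000 nM in this assay for now.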

Compound 3, concentration for 50% growth inhibition: 6400 nM
Estimate against measurement, compound 3: 1.1-fold (0.04 log units) above; low and high end bracket the measured number.
By their numbers in this assay, from the lowest: compound 2; then compound 3; then compound 1.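

In this assay the exchange of trifluoromethyl for methyl on the oxygen gives a 2.1-fold higher number from compound 2 to compound 3 (0.31 log units; beyond the scatter) and so weakens growth inhibition only modestly. Methoxy in place of fluoro still gives a 3.5-fold lower number from compound 1 to compound 3 (0.54 log units; beyond the scatter) and this puts methoxy between the two earlier groups, with the numbers rising from trifluoromethoxy through methoxy to fluoro. No measurement shown here accounts for this order, so its cause stays unknown.

These three groups give only a narrow view of this end of the molecule. A longer chain on the oxygen, such as ethoxy or butoxy, or an amine or a carboxylic acid on the aromatic carbon, could continue this order or break it.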